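The source may hold more compounds than are shown below. What is called first, only, known or untested is meant among the compounds shown, and "the series" means these compounds.

Compound 1 `COc1cc(OC2CCC2)nc(-c2ccc3c(c2)CC[C@H](CCC(=O)O)O3)c1F` carries a 2-carboxyethyl chain on its core. In a functional assay on HEK293 cells for agonist activity at Free fatty acid receptor 1 (Homo sapiens), read by HTRF and inositol phosphate accumulation, with a stated time of 60 min (on this read-out lower numbers stand for an effect already at smaller amounts and higher numbers for an effect only at larger amounts of compound), compound 1 gives only a limit, > 10000 nM. Compound 2 `COc1cc(O[C@H]2C[C@H](OC)C2)nc(-c2ccc3c(c2)CC[C@H](CCC(=O)O)O3)c1F` also gives only a limit in this assay, > 10000 nM. Compound 3 `COc1cc(OC2CC2)cc(-c2ccc3c(c2)CC[C@H](CCc2nnn[nH]2)O3)c1F` likewise gives only a limit, > 10000 nM, so that the limit of > 10000 nM in this assay, at which 3 of the 3 values shown sit, covers everything measured here. Compound 4 `COc1cc(OC2CCC2)nc(-c2ccc3c(c2)CC[C@H]([C@@H]2C[C@H]2C(=O)O)O3)c1F` is not yet measured; it differs from compound 1 by 2-carboxycyclopropyl in place of 2-carboxyethyl on a saturated ring carbon. The step that the two limits leave unreadable from compound 1 to compound 2 lies between two limits and cannot be read. Among the measured compounds shown here, no measured step therefore bears on the change to compound 4, and the expected step that the limit leaves unreadable from compound 1 to compound 4 is none beyond the scatter. Compound 4 is estimated at 12000 nM, with a range from 2000 nM to 40000 nM.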

Compound 4, half-maximal effective concentration: > 10000 nM
Compound 4: no number, only a limit; the forecaster's own chance of this, stated with the estimate: 65%; the middle value lies beyond the limit too.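

Among the compounds shown here, compound 1 and compound 4 both give only a limit, so no step between them can be read: the limit of > 10000 nM in this assay, at which 4 of the 4 values shown sit. The compounds shown leave open which structure, if any, would give an actual number in this assay.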